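This account rests on a few compounds, and the source may have more. Where it says the series, first, only, none or still open, it means among the compounds named here.

The measured compounds:

compound 1 `CCC(=O)N[C@@H]1CCCc2c1cncc2N1C(=O)c2ccc(Cl)cc2[C@@H]1C`, which in an assay on cells for inhibition of cytochrome P450 11B2, mitochondrial (Homo sapiens), read by HTRF (on this read-out higher numbers stand for weaker inhibition and lower numbers for stronger inhibition), gives 6 nM
compound 2 `CC(=O)N[C@@H]1CCCc2c1cncc2N1C(=O)c2ccc(Cl)cc2[C@@H]1C`, which in this assay gives 4 nM
compound 3 `CC(=O)N1CCC(c2cncc(N3C(=O)c4ccc(Cl)cc4C3(C)C)c2)CC1`, which in this assay gives 5 nM

Compound 2 has the lowest of the three numbers, but its margins are small: compound 3 sits a little higher and compound 1 a little higher still, and both of these gaps lie within the scatter of repeated measurements, so no order among the three can be read from them. Among the measured compounds shown here, the one single-point step among them, a 1.5-fold lower number from compound 1 to compound 2 (0.18 log units; within the scatter), concerns the amide side chain and also stays within the scatter.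

Compound 4 `CC(=O)N[C@@H]1CCCc2c1cncc2N1Cc2cc(Cl)ccc2C1=O` differs from compound 2 by hydrogen in place of methyl on a saturated ring carbon; in short, hydrogen in place of methyl on a saturated ring carbon. For the measured compounds named here, no measured step touches this position: the step from compound 1 to compound 2 removes a methyl elsewhere, and compound 3 carries two methyls at the corresponding ring carbon but also differs in its core, so its value can only be noted beside that of compound 2, not read as a step. The expectation for compound 4 therefore rests on little: a change of a 2.5-fold higher number from compound 2 to compound 4 (0.40 log units; beyond the scatter) is estimated, with a wide range. Compound 4 is expected to give 10 nM, between 3 nM and 40 nM.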

Compound 4, half-maximal inhibitory concentration: 44 nM
Compound 4: the middle estimate sits 4.4-fold (0.64 log units) below what was measured, and the stated range ends below it.
By their numbers in this assay, from the lowest: compounds 2, 3 and 1 (each within the scatter of the next); then compound 4.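

The methyl on this saturated ring carbon, next to the ring nitrogen and next to the ring atom that bears a large group, proves to matter in this assay: hydrogen in its place gives an 11-fold higher number from compound 2 to compound 4 (1.04 log units; beyond the scatter), and this is the only step shown that lies beyond the scatter. The other removal of a methyl among these compounds, on the amide side chain, gives a 1.5-fold lower number from compound 1 to compound 2 (0.18 log units; within the scatter) and stays within the scatter, so a change of this small size does not count the same at every place in these molecules. At this ring carbon, the loss of a single carbon atom, with no hydrogen-bond donor or acceptor and no charge involved, is enough to separate compound 4 from the other three compounds, and nothing given here accounts for the step.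

The compounds shown leave open whether an ethyl or a hydroxymethyl group on this ring carbon would give a number like that of compound 2 or a higher one, and what the opposite configuration of the methyl would give. They also leave open whether hydrogen in place of methyl here would give a step of similar size alongside the propanamide side chain of compound 1.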